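This account rests on a few compounds, and the source may have more. Where it says the series, first, only, none or still open, it means among the compounds named here.

Four compounds share a core, and they were compared for how strongly they harm liver-derived human cells. Compound 1 `O=C1/C(=C/c2ccc(F)cc2)CCC/C1=C\c1cccc([N+](=O)[O-])c1` and compound 2 `O=C1/C(=C/c2ccc(Cl)cc2)CCC/C1=C\c1cccc([N+](=O)[O-])c1` differ only in chloro in place of fluoro on an aromatic carbon. In an ADME assay on HPC cells (Homo sapiens) for cytotoxicity, with a stated time of 24 h (on this read-out lower numbers stand for higher toxicity in this test and higher numbers for lower toxicity in this test), compound 1 gives 38000 nM, and compound 2 gives 18000 nM. That change brought a 2.1-fold lower number from compound 1 to compound 2 (0.32 log units; beyond the scatter), so compound 2 reads as somewhat more toxic in this assay than compound 1.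

Compound 3 `O=C1/C(=C/c2ccc(F)cc2)CCC/C1=C\c1ccc([N+](=O)[O-])cc1` is made of the same atoms as compound 1, joined differently; how the two cores differ is not broken down here. In this assay compound 3 returns only a limit, > 400000 nM, and not a number. Among the compounds with values here, compound 3 is the one compound among the three measured that sits at the limit of > 400000 nM in this assay, at which 1 of the 3 values shown sits.

Compound 4 `O=C1/C(=C/c2ccc(Cl)cc2)CCC/C1=C\c1ccc([N+](=O)[O-])cc1` is the not yet measured partner of compound 3, differing from it by chloro in place of fluoro on an aromatic carbon. Within the data shown here, this is the same change, at the same place, as the one from compound 1 to compound 2. The expected step from compound 3 to compound 4 in this assay is an at least 1.3-fold lower number from compound 3 to compound 4 (0.12 log units; that floor lies within the scatter), judged against the modest measured step of a 2.1-fold lower number from compound 1 to compound 2 (0.32 log units; beyond the scatter). Because compound 3 reports only the limit > 400000 nM, the starting point is itself uncertain, and compound 4 may well also return only a limit. For compound 4 the estimate is 300000 nM, with a likely range from 100000 nM to 1000000 nM.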

Compound 4, half-maximal cytotoxic concentration: 345000 nM
Beside the measured number, compound 4's estimate is 1.2-fold (0.06 log units) below it, and the stated range covers the measured number.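

Chloro in place of fluoro on the core of compound 3 brought an at least 1.1-fold lower number from compound 3 to compound 4 (0.06 log units; that floor lies within the scatter), which points the same way as the step on the core of compound 1 but is too small, at its floor, to stand out from the usual scatter. Set side by side, the two steps read: the same change on two cores in this assay, a 2.1-fold lower number (0.32 log units; beyond the scatter) from compound 1 to compound 2 and an at least 1.1-fold lower number (0.06 log units; that floor lies within the scatter) from compound 3 to compound 4; the limit leaves it open whether they differ. Compound 3 returns only a limit, > 400000 nM, and not a number, so this pair shows that the swap did not raise the reading on the second core, but it does not show that the change carries over with the same size, or with a different one.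

The compounds shown hold only fluoro and chloro at this place, so it remains open how a bromo group, a methyl group or an amine there would read in this assay, and two pairs are too few to say whether the step holds across the series. Going by these compounds, it is also open whether the swap would behave the same way on further cores, especially on any core whose compounds give real numbers rather than a limit.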